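A few compounds are considered here, and "the series" means these few. Any claim that something is new, unique, unknown or untested is made for them only; others in the source may bear on it.

Among the measured compounds shown here, compound 2, whose structure is `CSc1ccc(OC(C)(C)C2OCC(C/C=C\CCC(=O)O)C(c3cccnc3)O2)c([N+](=O)[O-])c1`, holds the lower of the two numbers known so far in an assay for inhibition of Thromboxane-A synthase (Homo sapiens), using microsomes; a higher number here means a weaker inhibitor, a lower number a stronger inhibitor. In this assay compound 2 gives 22 nM. For the measured compounds named here, its only companion is compound 1, with the structure `O=C(O)CC/C=C\CC1COC(c2ccco2)OC1c1cccnc1`, and in this assay compound 1 gives 164 nM, a gap that lies beyond the usual scatter of such measurements. The two compounds differ in more than one place, so the account can say only what their two values show, not which part of the difference carries the gap.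

The next compound, compound 3, has the structure `CC(C)(Oc1ccccc1O)C1OCC(C/C=C\CCC(=O)O)C(c2cccnc2)O1` and awaits measurement in this assay. It is related to compound 2 by a single change: a group of 7 heavy atoms (6 carbon, 1 oxygen; one six-membered aromatic ring of carbon only) in place of a group of 11 heavy atoms (7 carbon, 1 nitrogen, 2 oxygen, 1 sulfur; one six-membered aromatic ring of carbon only), on an oxygen on a saturated carbon. Going by the values given here, no step between measured compounds matches this change, so there is no direct precedent to lean on. The account expects the step of a 2.3-fold higher number from compound 2 to compound 3 (0.36 log units; beyond the scatter) to be a modest rise in the number, though a result within the scatter would not surprise. On that basis compound 3 is estimated at 50 nM, with a plausible range from 15 nM to 170 nM.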

Compound 3, half-maximal inhibitory concentration: 32 nM
Beside the measured number, compound 3's estimate is 1.6-fold (0.19 log units) above it, within the range that was stated.
By their numbers in this assay, from the lowest: compounds 2 and 3 (each within the scatter of the next); then compound 1.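

In this assay, putting 2-hydroxyphenyl in place of the group of 11 heavy atoms, on an oxygen on a saturated carbon, gives a 1.5-fold higher number from compound 2 to compound 3 (0.16 log units; within the scatter), so the two compounds cannot be told apart by their numbers even though the entering group is the smaller one by heavy-atom count. Among the compounds shown here, this is the first comparison here that isolates a single place, since the earlier pair differed in more than one, and it shows that this position can carry two quite different aromatic groups, one with a hydrogen-bond donor and one without, while the values stay within the scatter. No measurement is available that would explain this outcome.

The compounds shown do not tell whether the hydroxyl of the 2-hydroxyphenyl contributes anything at all, which a plain phenyl or a 2-methoxyphenyl at this place would help to settle. They also leave open how far this position stretches, for instance to a ring bearing an amine or a carboxylic acid, or to a chain with no aromatic ring in it.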